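The source may report more compounds than this note shows. Statements on the series, on what has been measured and on what is new or still open speak of the compounds shown alone.

Measured compounds in an assay on membranes from CHO cells for displacement of a labelled ligand from adenosine receptor A1 (Homo sapiens), read by scintillation counting, with a stated time of 60 min, tested at 1 uM; a higher number here means more inhibition at the concentration tested (going by the name of the read-out), a lower number less inhibition:
- compound 1 `CC1=C(C(=O)OC(C)(C)C)C(c2ccco2)NC(=O)N1C` gives 44%
- compound 2 `COC(=O)C1=C(C)N(C)C(=O)NC1c1cccs1` gives 30%
- compound 3 `CCOC(=O)C1=C(C)N(C)C(=O)NC1c1cccs1` gives 1%

Compound 3 stands lowest of the three, with compound 2 nearest and compound 1 furthest, both steps beyond the scatter. Compound 4 `CC1=C(C(=O)OC(C)(C)C)C(c2cccs2)NC(=O)N1C` has not yet been measured in this assay. It differs from compound 3 in one place: tert-butyl in place of ethyl on an oxygen next to a carbonyl group.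

Within the data shown here, one measured step bears on this change: a number 29 percentage points lower from compound 2 to compound 3 (beyond the scatter), where the group on the same oxygen grew by one carbon and the number fell. Lengthening the same group further would, on that step alone, suggest a further fall or no rise. Against that, compound 1 already carries the tert-butoxycarbonyl group and gives 44%, although it differs from compound 4 elsewhere, so no step connects them. The measured step and the value of compound 1 point in opposite directions, so a small rise toward the level of compound 2 is expected, with wide uncertainty. For compound 4 the estimate is 25%, in the range 0% to 55%, which means an expected step of a number 24 percentage points higher from compound 3 to compound 4 (beyond the scatter).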

Compound 4, a percentage reported as inhibition, at one concentration (the size of the read-out at that concentration, not a potency): 18%
Compound 4: the middle estimate sits 7 percentage points above what was measured; the measured number falls inside the stated range.
By their numbers in this assay, from the lowest: compound 3; then compound 4; then compound 2; then compound 1.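

In this assay the group on this oxygen does not push the number in one direction: a number 29 percentage points lower from compound 2 to compound 3 (beyond the scatter) with ethyl in place of methyl, but tert-butyl in place of ethyl gives a number 17 percentage points higher from compound 3 to compound 4 (beyond the scatter) and tert-butyl in place of methyl gives a number 12 percentage points lower from compound 2 to compound 4 (beyond the scatter), so with thiophen-2-yl held fixed, ethyl sits lowest of the three groups. Compound 1 now has a direct partner, and thiophen-2-yl in place of furan-2-yl on a saturated ring carbon gives a number 26 percentage points lower from compound 1 to compound 4 (beyond the scatter), which shows that this ring also changes the number while tert-butyl stays in place. No measurement shown here explains either shift.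

On these data alone, how isopropyl or a longer chain such as butyl on this oxygen would read remains open. So does whether the furan-2-yl series would follow the same order with methyl and ethyl, or how a carboxylic acid would read in place of the ester.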